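Compound 3: bicyclic group on the amide-type nitrogen

The source may report more compounds than this note shows. Statements on the series, on what has been measured and on what is new or still open speak of the compounds shown alone.

In a functional assay on the whole organism (blood) with Rattus norvegicus as the target, with stated times of 24 h and 1 h, at a dose of 5 mg/kg by the intraperitoneal route (a lower number here means a weaker effect, a higher number a stronger effect of the compound at the dose given), compound 2 `COc1ncccc1C(=O)NCCC1CCN(S(=O)(=O)NC(=O)NC2CCCCC2)CC1` gives 33%. Compound 1 `O=C(NC1CCCCC1)NS(=O)(=O)N1CCC(CCNC(=O)c2cscn2)CC1` gives 23%; the step is a number 10 percentage points higher from compound 1 to compound 2 (within the scatter), so the two stand together within the scatter. Compound 3 `COc1ncccc1C(=O)NCCC1CCN(S(=O)(=O)NC(=O)NC[C@H]2C[C@@H]3C=C[C@@H]2C3)CC1` differs from compound 2 by a group of 8 heavy atoms (8 carbon; 2 five-membered non-aromatic rings of carbon only) in place of a group of 6 heavy atoms (6 carbon; one six-membered non-aromatic ring of carbon only), on an amide-type nitrogen. Going by the values given here, the one measured step concerns the group on the carbonyl carbon, not this nitrogen, so no measured step bears directly on the change, and the series gives no ground for a shift beyond the scatter in this assay. The expected step is no change at the digits printed from compound 2 to compound 3 (within the scatter), nothing beyond the scatter. The estimate for compound 3 is 33%, range 15% to 50%.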

Compound 3, a percentage reported as activity, at one dose (the size of the read-out at that dose, not a potency): 20%
Estimate against measurement, compound 3: 13 percentage points above; the range from low to high includes it.
By their numbers in this assay, from the lowest: compounds 3, 1 and 2 (each within the scatter of the next, the first and the last beyond it).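

In this assay, going by these compounds alone, the substituent on the amide-type nitrogen proves able to move the read-out: the change from cyclohexyl gives a number 13 percentage points lower from compound 2 to compound 3 (beyond the scatter), whereas the one step on the carbonyl carbon stayed within the scatter. The group with two five-membered non-aromatic rings is therefore less favourable than cyclohexyl in this pair, though the step is modest and rests on a single comparison. Nothing available accounts for the drop.

Open, from the compounds shown here alone, is whether a phenyl ring or a straight hexyl chain on this nitrogen would retain the effect. Also open, going by these compounds, is whether the step holds with 1,3-thiazol-4-yl on the carbonyl carbon.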